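Replacing the trifluoromethyl-triazole with a triazolone on the ether

A few compounds are considered here, and "the series" means these few. Any claim that something is new, unique, unknown or untested is made for them only; others in the source may bear on it.

Compound 1, `CCC(C)(C)Cc1c[nH]c(CCc2ccc(-c3ccccc3O)cc2)n1`, gives 133 nM in a functional assay for agonist activity at Bombesin receptor subtype-3 (Homo sapiens); a higher number here means that more compound is needed for the effect, a lower number that less compound is needed. Compound 2, `CCC(C)(C)Cc1c[nH]c(CCc2ccc(-c3ccccc3OCc3ncn[nH]3)cc2)n1`, gives 172 nM in this assay. Compound 3, `CCC(C)(C)Cc1c[nH]c(CCc2ccc(-c3ccccc3OCc3nc(C(F)(F)F)n[nH]3)cc2)n1`, gives 129 nM in this assay.

Compound 3 is separated from compound 1 by a 1.0-fold lower number from compound 1 to compound 3 (0.01 log units; within the scatter) and from compound 2 by a 1.3-fold lower number from compound 2 to compound 3 (0.12 log units; within the scatter); the three numbers sit within the usual scatter of one another, and the step of a 1.3-fold higher number from compound 1 to compound 2 (0.11 log units; within the scatter) is likewise small. Compound 4, `CCC(C)(C)Cc1c[nH]c(CCc2ccc(-c3ccccc3OCc3nc(=O)[nH][nH]3)cc2)n1`, has not yet been measured. It differs from compound 3 in that (a group of 6 heavy atoms (2 carbon, 3 nitrogen, 1 oxygen; one five-membered aromatic ring with 3 hetero atoms) in place of a group of 9 heavy atoms (3 carbon, 3 nitrogen, 3 fluorine; one five-membered aromatic ring with 3 hetero atoms), on a saturated chain carbon bound to an oxygen on an aromatic ring). For the measured compounds named here, the steps that bear on this change are those at the same position: the addition of the triazolylmethyl group in a 1.3-fold higher number from compound 1 to compound 2 (0.11 log units; within the scatter), its trifluoromethyl variant in a 1.0-fold lower number from compound 1 to compound 3 (0.01 log units; within the scatter), and the swap between the two triazoles in a 1.3-fold lower number from compound 2 to compound 3 (0.12 log units; within the scatter), none of which moved the number beyond the scatter. For compound 4 the step of a 1.2-fold higher number from compound 3 to compound 4 (0.07 log units; within the scatter) is therefore expected to stay within the scatter. The estimated value for compound 4 is 150 nM, with a range from 60 nM to 400 nM.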

Compound 4, half-maximal effective concentration: 336 nM
The estimate for compound 4 lay 2.2-fold (0.35 log units) below the measured number, within the range that was stated.
By their numbers in this assay, from the lowest: compounds 3, 1, 2 and 4 (each within the scatter of the next, the first and the last beyond it).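

For the compounds shown here, until now, the oxygen on the aromatic ring had taken both triazolylmethyl groups without any step beyond the scatter, and the triazolone is the first group there to produce one. In this assay, replacing the 3-(trifluoromethyl)-1H-1,2,4-triazol-5-yl group gives a modest loss (a 2.6-fold higher number from compound 3 to compound 4 (0.42 log units; beyond the scatter)), and the whole group in place of the hydrogen on that oxygen gives a similar one (a 2.5-fold higher number from compound 1 to compound 4 (0.40 log units; beyond the scatter)), while the comparison with the unsubstituted triazole of compound 2 stays inside the scatter (a 2.0-fold higher number from compound 2 to compound 4 (0.29 log units; within the scatter)). The position therefore does tolerate changes unevenly, though only modestly, and nothing available here accounts for this.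

The compounds shown leave open whether an amine or a carboxylic acid on the same ring would behave like the carbonyl of compound 4. They also leave open how a longer chain between the oxygen and the ring would read in this assay.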